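Aryloxymethyl variation on the shared core, agonist potency

The compounds below may be only part of what the source reports. "The series", "measured", "known", "first", "only" and "open" are said of these compounds alone.

Measured compounds:
compound 1, `O=C(O)CCc1ccc(NC(=O)c2nnc(COc3cccc(Cl)c3)s2)cc1`, 1570 nM
compound 2, `COc1ccc(OCc2nnc(C(=O)Nc3ccc(CCC(=O)O)cc3)s2)cc1`, 2430 nM

In a functional assay on CHO cells for agonist activity at Free fatty acid receptor 1 (Homo sapiens), read by FLIPR and calcium flux, tested at 1 uM (a higher number here means that more compound is needed for the effect, a lower number that less compound is needed), compound 2 gives the highest of the two numbers, its nearest neighbour being compound 1, with the step of a 1.5-fold higher number from compound 1 to compound 2 (0.19 log units; within the scatter). Compound 3, `Cc1ccccc1OCc1nnc(C(=O)Nc2ccc(CCC(=O)O)cc2)s1`, differs from compound 2 by 2-methylphenyl in place of 4-methoxyphenyl on an oxygen on a saturated carbon. Going by the values given here, only the step from compound 1 to compound 2 bears on this change; it stayed within the scatter, so no shift beyond the scatter is expected for a 1.2-fold lower number from compound 2 to compound 3 (0.08 log units; within the scatter). For compound 3 the estimate in this assay is 2000 nM, within 900 nM to 4500 nM.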

Compound 3, half-maximal effective concentration: 1520 nM
Compound 3: middle estimate off by 1.3-fold (0.12 log units), on the high side, and the stated range covers the measured number.
By their numbers in this assay, from the lowest: compounds 3, 1 and 2 (each within the scatter of the next).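

In this assay the aryl group on the oxygen now spans three forms, and both a 1.6-fold lower number from compound 2 to compound 3 (0.20 log units; within the scatter) and a 1.0-fold lower number from compound 1 to compound 3 (0.01 log units; within the scatter) stay within the scatter. Going by these compounds alone, an ortho-free wording applies only to the names: 2-methylphenyl reads the same as 4-methoxyphenyl and 3-chlorophenyl at this place, so a third substituted phenyl adds no separation among the compounds. No supporting data bear on this flat reading.

Open, as far as these compounds go, is whether a phenyl carrying an amine or a carboxylic acid, or a longer chain on the oxygen, would move the number beyond the scatter.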